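Working notes: adding methylsulfonyl to compound 2

The source may hold more compounds than are shown below. What is called first, only, known or untested is meant among the compounds shown, and "the series" means these compounds.

Measured in a functional assay on ASPC1 cells (Homo sapiens) for cytotoxicity; on this read-out lower numbers stand for stronger inhibition and higher numbers for weaker inhibition:
- compound 1 `COc1ccc2nc(NC(=O)CCCCC(=O)NO)sc2c1`: 23.9 ug/mL
- compound 2 `O=C(CCCCCCC(=O)Nc1nc2ccccc2s1)NO`: 5.69 ug/mL

Compound 2 has the lower number of the two, and its gap to compound 1 lies beyond the scatter. Compound 3 `CS(=O)(=O)c1ccc2nc(NC(=O)CCCCCCC(=O)NO)sc2c1` differs from compound 2 in one place: methylsulfonyl in place of hydrogen on an aromatic carbon, with methylsulfonyl in place of hydrogen on an aromatic carbon. Among the compounds with values here, no measured pair shows this change, so in this assay no step beyond the scatter is expected, and no direction is favoured. The expected change is a 1.1-fold higher number from compound 2 to compound 3 (0.02 log units; within the scatter). For compound 3 the estimated value is 6 ug/mL, with an expected range of 2 ug/mL to 18 ug/mL.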

Compound 3, half-maximal inhibitory concentration: 13.5 ug/mL
Beside the measured number, compound 3's estimate is 2.3-fold (0.35 log units) below it; the measured number falls inside the stated range.
By their numbers in this assay, from the lowest: compound 2; then compounds 3 and 1 (each within the scatter of the next).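

In this assay, this aromatic carbon now has its first one-place comparison: methylsulfonyl in place of hydrogen gives a 2.4-fold higher number from compound 2 to compound 3 (0.38 log units; beyond the scatter), a modest step. Substitution here is therefore not neutral for this group, though the number stays of the same general order. Nothing measured bears on the reason for the step.

The compounds shown leave open whether the step belongs to methylsulfonyl specifically or to any group on this carbon. An amine or a carboxylic acid at the same place would separate those two readings.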